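The source may hold more compounds than are shown below. What is called first, only, known or untested is meant among the compounds shown, and "the series" means these compounds.

Of the compounds shown here, three have so far been tested in an ADME assay on HEK-293T cells (Homo sapiens) for cytotoxicity, read by CCK-8 assay, with a stated time of 48 h; a higher number here means a weaker inhibitor, a lower number a stronger inhibitor. Compound 3 `CC(C)c1ccc(Oc2ccc(O)c(O)c2)c(-c2ccsc2S(=O)(=O)NCCNC(=S)Nc2ccc([N+](=O)[O-])cc2)c1` gives 16300 nM in this assay, and compound 1 `COc1ccc(Oc2ccc(C(C)C)cc2-c2ccsc2S(=O)(=O)NCCNC(=S)Nc2ccc([N+](=O)[O-])cc2)cc1OC` gives 11400 nM. The two differ in a single place, (3,4-dimethoxyphenyl in place of 3,4-dihydroxyphenyl on an oxygen on an aromatic ring), and that change made a 1.4-fold lower number from compound 3 to compound 1 (0.16 log units; within the scatter). Compound 2 `Cc1ccc(-c2ccsc2S(=O)(=O)NCCNC(=O)Nc2cc(C(F)(F)F)cc(C(F)(F)F)c2)c(Oc2ccc(O)c(O)c2)c1` reaches only a limit of this assay, > 20000 nM, which is not a number. That limit is the limit of > 20000 nM in this assay, at which 1 of the 3 values shown sits. The difference between the core of compound 2 and the core of compound 3 is not broken down here. Compound 4 `COc1ccc(Oc2cc(C)ccc2-c2ccsc2S(=O)(=O)NCCNC(=O)Nc2cc(C(F)(F)F)cc(C(F)(F)F)c2)cc1OC` has not yet been measured; it carries the same change that separates compound 1 from compound 3, namely (3,4-dimethoxyphenyl in place of 3,4-dihydroxyphenyl on an oxygen on an aromatic ring). Because that change made only a 1.4-fold lower number from compound 3 to compound 1 (0.16 log units; within the scatter), the expected step is a step that the limit leaves unreadable from compound 2 to compound 4. Compound 4 is therefore estimated to give about 22000 nM, with a limit rather than a number a likely outcome.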

Compound 4, half-maximal inhibitory concentration: 9000 nM
Compound 4: middle estimate off by 2.4-fold (0.39 log units), on the high side; the measured number lies below the stated range.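

In this assay, putting 3,4-dimethoxyphenyl in place of 3,4-dihydroxyphenyl gave an at least 2.2-fold lower number from compound 2 to compound 4 (0.34 log units; beyond the scatter), so on this core the change moved the number by more than the usual scatter. Set beside the earlier core, the result reads: the same change on two cores in this assay, a 1.4-fold lower number (0.16 log units; within the scatter) from compound 3 to compound 1 and an at least 2.2-fold lower number (0.34 log units; beyond the scatter) from compound 2 to compound 4; the limit leaves it open whether they differ. From the compounds shown here alone, compound 2 gives > 20000 nM, a limit and not a number; the full size of the step on this core stays unknown, and two cores make no rule for the series.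

The compounds shown leave open whether replacing only one of the two hydroxy groups with methoxy would give the same step. Also open, going by these compounds, is how a 3,4-diethoxyphenyl group, or a phenyl carrying a carboxylic acid, would read on that oxygen.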